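From (oxetan-2-yl)methyl to sec-butyl on the shared core

The source may hold more compounds than are shown below. What is called first, only, known or untested is meant among the compounds shown, and "the series" means these compounds.

In a functional assay on FaDu cells (Homo sapiens) for cytotoxicity, read by MTT assay, with a stated time of 72 h (a lower number here means that less compound is tolerated, a higher number that more compound is tolerated), compound 3, `COc1ccc(NC(=O)C(=O)c2cn(CC3CCO3)c3ccccc23)cn1`, gives 686 nM. Compound 2, `COC(=O)CCn1cc(C(=O)C(=O)Nc2ccc(OC)nc2)c2ccccc21`, gives 168 nM. For the measured compounds named here, of these two numbers, the one for compound 3 is the higher, with a 4.1-fold higher number from compound 2 to compound 3 (0.61 log units; beyond the scatter). Compound 1, `COc1ccc(NC(=O)C(=O)c2cn(CC(C)(C)OC)c3ccccc23)cn1`, gives > 10000 nM, which is a limit and not a number.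

The next compound, compound 4, `CCC(C)n1cc(C(=O)C(=O)Nc2ccc(OC)nc2)c2ccccc21`, carries sec-butyl in place of (oxetan-2-yl)methyl on an aromatic nitrogen. Going by the values given here, two measured steps bear on this change. The side chain of compound 1 also lacks a ring, and this assay shows an at least 14-fold lower number from compound 1 to compound 3 (1.16 log units; beyond the scatter), a large step. Compound 2 goes against any simple link between a ring-free group and a high number, as a 4.1-fold higher number from compound 2 to compound 3 (0.61 log units; beyond the scatter) is a modest step in the opposite sense. These steps also concern groups on a saturated chain carbon bound to an aromatic nitrogen, so they transfer only loosely to a change made on the nitrogen itself. A modest rise is therefore expected, with wide uncertainty. The expected change is a 2.2-fold higher number from compound 3 to compound 4 (0.34 log units; beyond the scatter). For compound 4 the estimated value is 1500 nM, within an expected range from 250 nM to 9000 nM.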

Compound 4, concentration lethal to 50% of the cells: 68 nM
Compound 4: the middle estimate sits 22-fold (1.34 log units) above what was measured; the measured number lies below the stated range.
By their numbers in this assay, from the lowest: compound 4; then compound 2; then compound 3. At a limit, above all of these: compound 1.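

In this assay, the change to sec-butyl on the aromatic nitrogen brings a 10-fold lower number from compound 3 to compound 4 (1.00 log units; beyond the scatter), and the same group also gives a 2.5-fold lower number from compound 2 to compound 4 (0.39 log units; beyond the scatter), so the lowest number of the set now belongs to the only side chain shown without oxygen. The absence of a ring does not go with a low number on its own: 2-methoxy-2-methylpropyl also has no ring but stands at the other end of the set, with an at least 140-fold lower number from compound 1 to compound 4 (2.16 log units; beyond the scatter). For compound 1 the value is a limit and not a number: the limit of > 10000 nM in this assay, at which 1 of the 4 values shown sits.

The compounds shown leave open whether the low number goes with the branched shape of sec-butyl or simply with a side chain made of carbon alone, and a straight butyl chain or a cyclobutylmethyl group on the same nitrogen would help to separate these two readings. It also remains open how this position responds to a side chain ending in an amine or a carboxylic acid, as every side chain shown is either purely carbon or carries oxygen as an ether or an ester.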